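Swapping the aryl group on a dienone cytotoxicity series

The compounds below may be only part of what the source reports. "The series", "measured", "known", "first", "only" and "open" are said of these compounds alone.

Measured so far:
compound 1, `CC1=C(/C=C/C(=O)/C=C/c2ccc(Br)cc2)C(C)(C)CCC1`: 18900 nM
compound 2, `CC1=C(/C=C/C(=O)/C=C/c2ccc(C#N)cc2)C(C)(C)CCC1`: 11900 nM

Among the compounds with values here, in a functional assay on PC-3 cells (Homo sapiens) for cytotoxicity, read by sulforhodamine B assay, with a stated time of 48 h (a higher number here means a weaker inhibitor, a lower number a stronger inhibitor), compound 1 gives the higher of the two numbers, with compound 2 the only neighbour; the step of a 1.6-fold lower number from compound 1 to compound 2 (0.20 log units; within the scatter) lies within the scatter. Compound 3, `CC1=C(/C=C/C(=O)/C=C/c2ccccc2C)C(C)(C)CCC1`, differs from compound 1 by 2-methylphenyl in place of 4-bromophenyl on a double-bonded chain carbon bound to a double-bonded chain carbon. Within the data shown here, no measured step covers this change directly; the one known step, which kept the ring and swapped its substituent, was within the scatter, so in this assay compound 3 is expected to show no step beyond the scatter, a 1.3-fold lower number from compound 1 to compound 3 (0.10 log units; within the scatter). Compound 3 is therefore estimated at 15000 nM, between 5000 nM and 45000 nM.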

Compound 3, half-maximal inhibitory concentration: 44100 nM
Beside the measured number, compound 3's estimate is 2.9-fold (0.47 log units) below it; measured number inside the range.
By their numbers in this assay, from the lowest: compounds 2 and 1 (each within the scatter of the next); then compound 3.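

In this assay, within the data shown here, the swap to 2-methylphenyl on a double-bonded chain carbon bound to a double-bonded chain carbon gives the first step that lies beyond the scatter (a 2.3-fold higher number from compound 1 to compound 3 (0.37 log units; beyond the scatter)). The number at this position can therefore move with the aryl group, which the change from bromo to cyano did not show. No evidence on hand explains this step.

The group and its place on the ring both differ here, so the two changes cannot be separated. Going by these compounds, how an amine or a carboxylic acid on the ring would behave also remains open.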